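Naphthalenyl replaces methoxyphenyl on the dienone chain

This account rests on a few compounds, and the source may have more. Where it says the series, first, only, none or still open, it means among the compounds named here.

Measured compounds:
compound 1, `COc1ccccc1/C=C/C(=O)/C=C/c1ccc(OCc2cn(CCCCOc3cc(=O)oc4ccccc34)nn2)c(OC)c1`, 40%
compound 2, `COc1cc(/C=C/C(=O)/C=C/c2cccc3ccccc23)ccc1OCc1cn(CCCOc2cc(=O)oc3ccccc23)nn1`, 71%

In a functional assay on THP-1 cells (Homo sapiens) for inhibition, read by sulforhodamine B assay, with a stated time of 48 h, tested at 50 uM (on this read-out lower numbers stand for less inhibition of growth and higher numbers for more inhibition of growth at the one concentration tested), compound 1 gives 40%, the lowest of the two numbers; compound 2 gives 71%, a gap beyond the scatter. Compound 3, `COc1cc(/C=C/C(=O)/C=C/c2cccc3ccccc23)ccc1OCc1cn(CCCCOc2cc(=O)oc3ccccc23)nn1`, is not yet measured. It differs from compound 1 as follows: naphthalen-1-yl in place of 2-methoxyphenyl on a double-bonded chain carbon bound to a double-bonded chain carbon. Among the compounds with values here, no step between measured compounds covers this change, yet compound 2, which carries the same naphthalen-1-yl, gives 71%, so a rise beyond the scatter is expected for a number 25 percentage points higher from compound 1 to compound 3 (beyond the scatter). Compound 3 is estimated at 65%, within 45% to 85%.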

Compound 3, percent growth inhibition at one concentration: 54%
For compound 3 the middle estimate is 11 percentage points above the measured one; measured number inside the range.
By their numbers in this assay, from the lowest: compound 1; then compound 3; then compound 2.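

In this assay, the change from 2-methoxyphenyl to naphthalen-1-yl on a double-bonded chain carbon bound to a double-bonded chain carbon can now be read on its own, giving a number 14 percentage points higher from compound 1 to compound 3 (beyond the scatter) with the rest of the structure held constant. At this position, the second aromatic ring of naphthalen-1-yl is compatible with more growth inhibition, and the methoxy oxygen is not required for it. No available data explain the rise.

As far as these compounds go, whether a carboxylic acid or an amine on the phenyl ring at this position would match naphthalen-1-yl remains open. Also open, from the compounds shown here alone, is whether the step would hold with a longer chain to the triazole.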